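Removing the trifluoromethyl from compound 1: an expectation

The source may hold more compounds than are shown below. What is called first, only, known or untested is meant among the compounds shown, and "the series" means these compounds.

Compound 1 `COc1ccc(Cn2cc3cc(C(=N)Nc4cccc(C(F)(F)F)c4)ncc3n2)cc1` was tested in a functional assay on PC-3 cells (Homo sapiens) for cytotoxicity, read by MTT assay, with a stated time of 72 h (a higher number here means a weaker inhibitor, a lower number a stronger inhibitor), and gave 12800 nM, which is the higher of the two numbers recorded in this set. Within the data shown here, the other measured compound, compound 2 `COc1ccc(Cn2nc(-c3ccccc3)c3cc(C(=N)Nc4ccccc4)nc(NC4CCCCC4)c32)cc1`, carries a differently built core and gave 1100 nM in this assay; the two values lie far apart, but the structures differ in several places at once, so no single step connects them.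

Compound 3 `COc1ccc(Cn2cc3cc(C(=N)Nc4ccccc4)ncc3n2)cc1` has not yet been measured in this assay. It differs from compound 1 in one place only: hydrogen in place of trifluoromethyl on an aromatic carbon. The shared core, the anisyl-methyl group and the amidine linkage are kept unchanged.

Among the measured compounds shown here, with no measured pair in this set showing what this particular change does, the expectation rests on the modest size of the change alone. The step from compound 1 to compound 3 is expected to be small, a 1.2-fold higher number from compound 1 to compound 3 (0.07 log units; within the scatter), and may well stay within the ordinary scatter of repeated measurements. Compound 3 is therefore estimated to give about 15000 nM in this assay, with a plausible range from 5000 nM to 40000 nM.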

Compound 3, half-maximal inhibitory concentration: 2040 nM
Estimate against measurement, compound 3: 7.4-fold (0.87 log units) above; the whole stated range lies above it.
By their numbers in this assay, from the lowest: compounds 2 and 3 (each within the scatter of the next); then compound 1.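

Among these compounds, replacing 3-(trifluoromethyl)phenyl with phenyl gives a 6.3-fold lower number from compound 1 to compound 3 (0.80 log units; beyond the scatter) in this assay, the first reading in this set of a change made in one place only. It shows that this position is not indifferent in this assay: on the shared core, trifluoromethyl is not needed for the cytotoxicity seen here, and in this single pair its presence goes with the weaker result. The compounds shown offer no measurement that explains why the number falls when the group leaves, so the step stands as an observation without a stated cause.

Among the compounds shown here, with only this pair, it remains open whether the outcome belongs to trifluoromethyl in particular or to any group at this place, and a single fluorine atom, a methyl, a methoxy or an amine there would help separate those readings. As far as these compounds go, it is equally open whether the same change would give a step of similar size on the core of compound 2, which differs from compound 3 in several places.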